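This account rests on a few compounds, and the source may have more. Where it says the series, first, only, none or still open, it means among the compounds named here.

Measured in a functional assay on AGS cells (Homo sapiens) for antiproliferative activity, read by MTT assay, with a stated time of 48 h; on this read-out higher numbers stand for weaker inhibition of growth and lower numbers for stronger inhibition of growth:
Compound 1 `COc1ccc(N(C)c2ncnc3c2ncn3C)cc1`: > 100000 nM
Compound 2 `COc1ccc(Cn2cnc3c(N(C)c4ccc(OC)cc4)ncnc32)cc1`: > 100000 nM
Compound 3 `COc1ccc(N(C)c2ncnc3c2ncn3Cc2ccc(OC)c(OC)c2)cc1`: > 100000 nM

Each of these entries is a limit of the assay and not a number. Compound 3 therefore has no exact position on the scale, only its limit of > 100000 nM. Within the data shown here, compound 1 and compound 2 are no better defined, so the series so far offers no measured potency to compare.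

Compound 4 `COc1ccc(N(C)c2ncnc3c2ncn3Cc2cc(OC)c(OC)c(OC)c2)cc1` is built from compound 3 by putting methoxy in place of hydrogen on an aromatic carbon.

Among the measured compounds shown here, the closest precedent is the same kind of change, a step that the two limits leave unreadable from compound 2 to compound 3. Two further steps are less direct, a step that the two limits leave unreadable from compound 1 to compound 2 and a step that the two limits leave unreadable from compound 1 to compound 3. None of the three has a readable size, and the overall picture is the limit of > 100000 nM in this assay, at which 3 of the 3 values shown sit. They give no sign of a gain in this assay, yet they cannot rule one out, since a change hidden beyond a limit cannot be seen. The most likely outcome is therefore another limit, with no readable step in either direction.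

The expected change is a number no higher from compound 3 to compound 4 (the limit leaves the size open).

For compound 4, the estimated value is 100000 nM, with an expected range from 30000 nM to 300000 nM.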

Compound 4, concentration for 50% growth inhibition: > 100000 nM
Compound 4: no number, only a limit (the forecaster's own chance of this, stated with the estimate: 75%); the middle value lies on the limit itself.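

Compound 3 and compound 4 both carry only a limit of the assay in this assay, so the step between them cannot be read and adding the methoxy shows no measurable change. The compounds shown leave open whether any change to this series gives a measurable inhibition of growth, and how large it would be, as every entry is the same: the limit of > 100000 nM in this assay, at which 4 of the 4 values shown sit.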